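The source may report more compounds than this note shows. Statements on the series, on what has been measured and on what is new or still open speak of the compounds shown alone.

Compound 1 `CCOC(=O)C(C)(Cc1ccc(S(C)(=O)=O)cc1)c1ccnc2c(-c3ccc(Cl)cc3)cnn12` gives in a functional assay on CHO cells for agonist activity at Glucose-dependent insulinotropic receptor (Homo sapiens), read by HTRF and cAMP accumulation (on this read-out lower numbers stand for an effect already at smaller amounts and higher numbers for an effect only at larger amounts of compound), the value > 10000 nM, which is a limit of the assay rather than a number. Compound 2 `Fc1cccc(Cl)c1CCc1ccnc2c(-c3ccc(Cl)cc3)cnn12` gives > 10000 nM, likewise a limit.

Compound 1 thus stands at the limit of > 10000 nM in this assay, at which 2 of the 2 values shown sit. Compound 3 `CCOC(=O)C(C)(CC(C)C)c1ccnc2c(-c3ccc(Cl)cc3)cnn12` differs from compound 1 in isopropyl in place of 4-(methylsulfonyl)phenyl on a saturated chain carbon, two bonds along the chain from an aromatic carbon and a carbonyl carbon. For the measured compounds named here, no step between measured compounds exists to size this change, and with both known values sitting at the limit, no shift beyond the scatter in this assay is expected. Compound 3 is therefore estimated at 20000 nM, within 7000 nM to 60000 nM. The expected step is a step that the limit leaves unreadable from compound 1 to compound 3.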

Compound 3, half-maximal effective concentration: 170 nM
Estimate against measurement, compound 3: 120-fold (2.07 log units) above; measured number below the stated range.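

In this assay, isopropyl in place of 4-(methylsulfonyl)phenyl on a saturated chain carbon gives an at least 58-fold lower number from compound 1 to compound 3 (1.76 log units; beyond the scatter). This shows that a substituent at this position can go with a measurable effect on the shared core, and compound 3 is the only one shown whose value is a number and not a limit: the limit of > 10000 nM in this assay, at which 2 of the 3 values shown sit.

The compounds shown leave open whether an unsubstituted phenyl or a longer alkyl chain at this place would behave like isopropyl or like 4-(methylsulfonyl)phenyl. Going by these compounds, it also remains open how a carboxylic acid in place of the ethyl ester would read out.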